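A few compounds are considered here, and "the series" means these few. Any claim that something is new, unique, unknown or untested is made for them only; others in the source may bear on it.

Compound 1 `C#CCSc1nnc(CC)n1N1C(=O)c2ccccc2C1=O`: in a functional assay on PC-3M cells (Homo sapiens) for cytotoxicity, read by MTT assay, with a stated time of 48 h (on this read-out lower numbers stand for stronger inhibition and higher numbers for weaker inhibition), compound 1 gives > 200000 nM, which is a limit of the assay and not a number.
Compound 2 `CCc1nnc(SCC(=O)c2ccc(Cl)cc2)n1N1C(=O)c2ccccc2C1=O`: in this assay compound 2 gives > 200000 nM, again a limit of the assay.
Compound 3 `C#CCSc1nnc(-c2cc(OC)c(OC)c(OC)c2)n1N1C(=O)c2ccccc2C1=O`: in this assay compound 3 gives > 200000 nM, likewise a limit of the assay.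

Compounds 1 and 2 share a core and differ in one place: (4-chlorophenyl)carbonyl in place of ethynyl on a saturated chain carbon bound to a sulfur. The step that the two limits leave unreadable from compound 1 to compound 2 cannot be read as a size, because of the limit of > 200000 nM in this assay, at which 3 of the 3 values shown sit. Compound 3 carries another core; how the core of compound 3 differs from the core of compound 1 is not broken down here.

Compound 4 `COc1cc(-c2nnc(SCC(=O)c3ccc(Cl)cc3)n2N2C(=O)c3ccccc3C2=O)cc(OC)c1OC` is not yet measured in this assay. It stands to compound 3 as compound 2 stands to compound 1, by the same change: (4-chlorophenyl)carbonyl in place of ethynyl on a saturated chain carbon bound to a sulfur. The place is the same in both pairs, on a saturated chain carbon bound to a sulfur.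

Going by the values given here, the expectation for compound 4 rests on one observation only: because of the limit of > 200000 nM in this assay, at which 3 of the 3 values shown sit, every value so far, including that of compound 3, sits at the limit, and the same change from compound 1 to compound 2 left compound 2 at that limit too. Among the compounds with values here, the step from compound 3 to compound 4 is therefore expected to be no more than a step that the limit leaves unreadable from compound 3 to compound 4, and compound 4 is expected to give about 300000 nM in this assay, within a range from 100000 nM to 1000000 nM, most likely reported again only as a limit.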

Compound 4, half-maximal inhibitory concentration: 20700 nM
For compound 4 the middle estimate is 14-fold (1.16 log units) above the measured one, and the stated range ends above it.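

In this assay, placing (4-chlorophenyl)carbonyl in place of ethynyl on a saturated chain carbon bound to a sulfur gives an at least 9.6-fold lower number from compound 3 to compound 4 (0.98 log units; beyond the scatter), and placing 3,4,5-trimethoxyphenyl in place of ethyl on an aromatic carbon gives an at least 9.6-fold lower number from compound 2 to compound 4 (0.98 log units; beyond the scatter). Going by these compounds alone, the same change on the core of compound 1 cannot be read as a size, since both ends of that step sit at the limit of the assay: the limit of > 200000 nM in this assay, at which 3 of the 4 values shown sit. So the series shows that the change goes with a lower number on the core of compound 3 and that only compound 4, which carries both groups, gives a measured number, but it does not show whether the change acts to the same extent on both cores, and the one readable pair cannot establish a rule.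

Left open is whether the chlorine on the phenyl ring of (4-chlorophenyl)carbonyl is needed, or whether a fluorine, a methoxy group or a plain hydrogen would serve there. Also open, on these data alone, is how an amine, a carboxylic acid or a longer chain would fare in place of that group on the core of compound 4.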